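The compounds below may be only part of what the source reports. "The series", "measured", "known", "first", "only" and "open" are said of these compounds alone.

Of the compounds shown here, three have been measured in a functional assay on MCF7 cells (Homo sapiens) for antiproliferative activity, read by MTT assay, with a stated time of 48 h; a higher number here means a weaker inhibitor, a lower number a stronger inhibitor. Compound 1, `COc1ccc(-c2nn(-c3ccccc3)cc2C(Nc2nc3ccccc3s2)c2c(O)ccc3ccccc23)cc1`, gives 17500 nM in this assay. Compound 2, `Oc1ccc2ccccc2c1C(Nc1nc2ccccc2s1)c1cn(-c2ccccc2)nc1-c1ccc(I)cc1`, gives 18900 nM. Compound 3, `COc1ccc2nc(NC(c3cn(-c4ccccc4)nc3-c3cccc(I)c3)c3c(O)ccc4ccccc34)sc2c1`, gives 20000 nM. All three numbers lie within the usual scatter of one another, so no ordering among them can be read from these data.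

Compound 1 and compound 2 differ in a single place: methoxy in place of iodo on an aromatic carbon. This change produced a 1.1-fold lower number from compound 2 to compound 1 (0.03 log units; within the scatter). How compound 3 differs from compound 2 involves more than one place, and the difference between the two cores is not broken down here.

Compound 4, `COc1cccc(-c2nn(-c3ccccc3)cc2C(Nc2nc3ccc(OC)cc3s2)c2c(O)ccc3ccccc23)c1`, has not yet been measured. It differs from compound 3 in one place: methoxy in place of iodo on an aromatic carbon. For the measured compounds named here, this is the same kind of change as the one from compound 2 to compound 1, but not the same: in compound 2 the iodo sits para to a large group, whereas in compound 3 it sits meta to a large group. Going by the values given here, with only one measured example of this kind of change, and with the core of compound 3 represented by a single measured value, the expectation rests on a thin base. The step in this assay is expected to be small, about a 1.1-fold lower number from compound 3 to compound 4 (0.05 log units; within the scatter), because a 1.1-fold lower number from compound 2 to compound 1 (0.03 log units; within the scatter) stayed within the scatter. Compound 4 is therefore estimated at 18000 nM in this assay, with a likely range from 9000 nM to 36000 nM.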

Compound 4, half-maximal inhibitory concentration: 62600 nM
Compound 4: middle estimate off by 3.5-fold (0.54 log units), on the low side; measured number above the stated range.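

In this assay, putting methoxy in place of iodo gave a 3.1-fold higher number from compound 3 to compound 4 (0.50 log units; beyond the scatter), so this change did not carry over at the same size from one core to the other: the same change on two cores in this assay, a 1.1-fold lower number (0.03 log units; within the scatter) from compound 2 to compound 1 and a 3.1-fold higher number (0.50 log units; beyond the scatter) from compound 3 to compound 4, 3.4-fold (0.53 log units) apart, beyond the scatter of two such steps On these two pairs, then, a small step on one core gave no safe guide to the step on the other, and a swap that made no readable difference in one pair made a readable difference in the other. This does not show what sets the two steps apart, or that the change generally depends on its surroundings: the pairs differ both in where the group sits on the phenyl ring and in the rest of the core, no pair shown separates these two differences, and each step rests on just one pair of values.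

The compounds shown leave open whether the step seen in the move from 3-iodophenyl to 3-methoxyphenyl belongs to methoxy itself or would also appear with another group in that place, such as an amine or a carboxylic acid. They also leave open how the same swap would behave at that ring place on the core of compound 1.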